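Dropping the Methoxy from Compound 2

The compounds below may be only part of what the source reports. "The series", "measured", "known", "first", "only" and "open" are said of these compounds alone.

Compound 2 `C#CCN(Cc1ccccc1)C1c2cccc(OC)c2OCC1(C)C` gives 4.3% in an assay on BTI cells for inhibition of Amine oxidase [flavin-containing] A (Homo sapiens), read by fluorescence, with a stated time of 20 min, tested at 1 uM (a lower number here means less inhibition, a higher number more inhibition at the concentration tested (going by the name of the read-out)), and there it stands alongside compound 1 `C#CCNC1c2cccc(OC)c2OCC1(C)C`, which gives 4.6%, the two within the scatter of each other, as the step of a number 0.3 percentage points lower from compound 1 to compound 2 (within the scatter) shows. Compound 3 `C#CCN(Cc1ccccc1)C1c2ccccc2OCC1(C)C` differs from compound 2 by hydrogen in place of methoxy on an aromatic carbon. Going by the values given here, no measured step touches the aromatic ring, so the one step recorded offers no direct guide, and with both measured numbers near the bottom of the scale no shift beyond the scatter is expected. For compound 3 the estimated inhibition is 5%, between 0% and 15%, an expected step of a number 0.7 percentage points higher from compound 2 to compound 3 (within the scatter).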

Compound 3, a percentage reported as inhibition, at one concentration (the size of the read-out at that concentration, not a potency): -10.6%
Beside the measured number, compound 3's estimate is 15.6 percentage points above it; the whole stated range lies above it.
By their numbers in this assay, from the lowest: compound 3; then compounds 2 and 1 (each within the scatter of the next).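

Going by these compounds alone, replacing methoxy with hydrogen on this aromatic carbon gives a number 14.9 percentage points lower from compound 2 to compound 3 (beyond the scatter) in this assay, the first change here to exceed the scatter, whereas benzyl on the amine nitrogen gave only a number 0.3 percentage points lower from compound 1 to compound 2 (within the scatter). Compound 3 at -10.6% falls below zero, so removing methoxy brings no gain in inhibition at the concentration tested. Nothing available explains this shift. From the compounds shown here alone, whether a hydroxyl or a chlorine on that carbon would read like compound 2 or compound 3 remains open. So does whether losing methoxy matters equally with hydrogen on the amine nitrogen, as in compound 1.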